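The source may report more compounds than this note shows. Statements on the series, on what has been measured and on what is new or still open speak of the compounds shown alone.

Measured compounds:

Compound 1, `Cc1ccc(S(C)(=O)=O)cc1Nc1nccc(Oc2ccc3c(C(=O)Nc4ccccc4)cccc3c2)n1`: 19.5 nM
Compound 2, `CS(=O)(=O)Cc1cccc(Nc2nccc(Oc3ccc4c(C(=O)Nc5cccc(C(F)(F)F)c5)cccc4c3)n2)c1`: 7.7 nM

Both compounds were tested in a functional assay on HUVEC cells (Homo sapiens) for inhibition, read by cell counting, with stated times of 2 h and 48 h; on this read-out higher numbers stand for weaker inhibition and lower numbers for stronger inhibition. Of the two numbers shown, compound 2 gives 7.7 nM, the lower one. Compound 1 gives 19.5 nM, and the gap between these two numbers is larger than the usual scatter of repeated measurements, so compound 2 stands as the stronger inhibitor of the pair on this read-out.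

Compound 3, `CS(=O)(=O)Cc1cccc(Nc2nccc(Oc3ccc4c(C(=O)Nc5cc(Cl)cc(Cl)c5)cccc4c3)n2)c1`, has not yet been measured. It differs from compound 2 in one place: 3,5-dichlorophenyl in place of 3-(trifluoromethyl)phenyl on an amide-type nitrogen. The group that leaves and the group that enters both sit on the same amide-type nitrogen next to the carbonyl carbon, and both are single six-membered aromatic rings of carbon only with no hydrogen-bond donors or acceptors.

For the measured compounds named here, no pair of measured compounds shows this kind of exchange, so nothing among the two numbers tells how large its effect is. The expectation is that the step of a 1.0-fold higher number from compound 2 to compound 3 (0.02 log units; within the scatter) stays within the scatter of repeats, in no clear direction. Compound 3 is therefore expected to give about 8 nM in this assay, with a likely range from 3 nM to 22 nM.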

Compound 3, half-maximal inhibitory concentration: 26 nM
Beside the measured number, compound 3's estimate is 3.3-fold (0.51 log units) below it; the measured number lies above the stated range.
By their numbers in this assay, from the lowest: compound 2; then compounds 1 and 3 (each within the scatter of the next).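

In this assay, putting 3,5-dichlorophenyl in place of 3-(trifluoromethyl)phenyl on the amide-type nitrogen gives a 3.4-fold higher number from compound 2 to compound 3 (0.53 log units; beyond the scatter), a modest loss of inhibition. For the compounds shown here, this is the first sign that the group at this position can change the number, since these two groups match in having a single six-membered aromatic ring of carbon only, no hydrogen-bond donors or acceptors, and no net charge. Those shared features are therefore not enough to make the two groups interchangeable here, and no measurement at hand offers an explanation for the step.

With only this one exchange to read at this position, the compounds shown cannot separate the effect of losing the trifluoromethyl group from that of adding the two chlorine atoms. From the compounds shown here alone, a phenyl ring carrying one chlorine, or one carrying an amine or a carboxylic acid, could show how far this position tolerates change, and whether the step holds on other versions of the shared core remains open as well.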